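This account rests on a few compounds, and the source may have more. Where it says the series, first, only, none or still open, it means among the compounds named here.

Measured compounds:
- compound 1, `COc1ccc(-c2oc3ccc(C(=O)O)cc3c(=O)c2O)cc1`: 24%
- compound 2, `Cc1ccc(-c2oc3ccc(C(=O)O)cc3c(=O)c2OC(C)C)cc1`: 8%

Of the compounds shown here, two sharing the same core have been tested in a functional assay on the whole organism (stomach) for inhibition, with Rattus norvegicus as the target, at a dose of 80 mg/kg; on this read-out higher numbers stand for more inhibition at the one dose given (going by the name of the read-out) and lower numbers for less inhibition. Compound 1 gives 24% in this assay, while compound 2 gives 8%. Compound 2 therefore stands lowest of the two numbers, and its gap to compound 1 lies beyond the usual scatter of the measurement.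

Compound 3, `COc1ccc(-c2oc3ccc(C(=O)O)cc3c(=O)c2OC(C)C)cc1`, has not yet been measured. It differs from compound 2 in a single place: methoxy in place of methyl on an aromatic carbon. Compound 3 also shares with compound 1 the methoxy group, but carries the isopropoxy group of compound 2 on the core.

Within the data shown here, with no measured step of this exact kind to lean on, only a small change is expected, estimated as a number 5 percentage points higher from compound 2 to compound 3 (within the scatter), upward but hardly beyond the scatter. Compound 3 is therefore expected to give about 13% in this assay, likely between 0% and 30%.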

Compound 3, a percentage reported as inhibition, in the whole organism at one dose (the size of the read-out at that dose, not a potency): 35%
For compound 3 the middle estimate is 22 percentage points below the measured one; measured number outside the range, above it.
By their numbers in this assay, from the lowest: compound 2; then compound 1; then compound 3.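

Swapping 4-methylphenyl for 4-methoxyphenyl, on an aromatic carbon para to a large group, gives a number 27 percentage points higher from compound 2 to compound 3 (beyond the scatter) in this assay, so this position clearly affects the read-out, which compound 1 and compound 2 could not show because they differ in two places. With the methoxy group kept, isopropyl in place of hydrogen on the oxygen gives a number 11 percentage points higher from compound 1 to compound 3 (beyond the scatter), so in this pair the added isopropyl goes with more inhibition, not less. Nothing available explains either step.

As far as these compounds go, whether methoxy is special at this position remains open, since an ethoxy group, a hydroxyl or a chlorine atom there could read differently. It is also unknown whether the isopropyl step would hold alongside the methyl group, or whether a longer chain such as butyl on that oxygen would change the read-out further.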